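A silicon group on the oxygen of compound 1

The source may report more compounds than this note shows. Statements on the series, on what has been measured and on what is new or still open speak of the compounds shown alone.

Compound 1 (`COc1ccc(C2=C(c3cc(OC)c(OC)c(OC)c3)CC(O)C2=O)cc1[N+](=O)[O-]`) was tested in an ADME assay on MIA PaCa-2 cells (Homo sapiens) for cytotoxicity, read by MTT assay, with a stated time of 72 h; a higher number here means a weaker inhibitor, a lower number a stronger inhibitor. In this assay compound 1 gives > 100 ug/mL, which is a limit of the assay and not a number. Compound 2 (`COc1ccc(C2=C(c3cc(OC)c(OC)c(OC)c3)C(=O)C(O)C2)cc1Cl`) gives > 100 ug/mL, also a limit. Compound 3 (`COc1ccc(C2=C(c3cc(OC)c(OC)c(OC)c3)C(=O)CC2OC(C)=O)cc1NC=O`), which carries an acetyl group on an oxygen and differs in other places too, gives a true number, 2 ug/mL.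

Compound 4 (`COc1ccc(C2=C(c3cc(OC)c(OC)c(OC)c3)CC(O[SiH2]C(C)(C)C)C2=O)cc1[N+](=O)[O-]`) is compound 1 with a single change: a group of 5 heavy atoms (4 carbon, 1 silicon; no ring) in place of a hydrogen atom, on an oxygen on a saturated carbon. Within the data shown here, its free hydrogen on that oxygen is gone, as it is in compound 3, so compound 3 at 2 ug/mL is the only guide here. One compound is thin support, and the limit hides the true starting value of compound 1. Even so, a step toward stronger inhibition in this assay, beyond the usual scatter, is expected rather than no change. The expected step is an at least 6.6-fold lower number from compound 1 to compound 4 (0.82 log units; beyond the scatter). For compound 4 the estimated value is 15 ug/mL, with an expected range from 2 ug/mL to 100 ug/mL.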

Compound 4, half-maximal inhibitory concentration: > 100 ug/mL
Compound 4 ended at the assay's limit; the forecaster's own chance of this, stated with the estimate: 35%; at least 6.6-fold (0.82 log units) between middle value and limit.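

Compound 1 and compound 4 both stand at a limit in this assay, so no step can be read between them: the limit of > 100 ug/mL in this assay, at which 3 of the 4 values shown sit.

The compounds shown leave open whether the silicon group on the oxygen changes the strength of inhibition at all, in either direction.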